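Cytotoxicity notes: methoxy in place of chloro on an aryl amide

A few compounds are considered here, and "the series" means these few. Any claim that something is new, unique, unknown or untested is made for them only; others in the source may bear on it.

compound 1 `C#CCNC(=O)c1csc(C#Cc2ccccc2)n1`: > 40000 nM
compound 2 `C#CCNC(=O)c1csc(Br)n1`: > 40000 nM
compound 3 `C#Cc1nc(C(=O)Nc2ccc(Cl)cc2)cs1`: 540 nM

In a functional assay on NCI-H522 cells (Homo sapiens) for cytotoxicity, with a stated time of 3 days (a lower number here means a stronger inhibitor, a higher number a weaker inhibitor), compound 1 gives only a limit, > 40000 nM. Compound 2 also gives only a limit in this assay, > 40000 nM. Among the measured compounds shown here, compound 3 is the single compound with a number, 540 nM. The other two stand at the limit of > 40000 nM in this assay, at which 2 of the 3 values shown sit. Compound 4 `C#Cc1nc(C(=O)Nc2ccc(OC)cc2)cs1` is not yet measured; it differs from compound 3 by methoxy in place of chloro on an aromatic carbon. For the measured compounds named here, no two measured compounds differ in one place, so no measured step is at hand. The step of a 1.9-fold higher number from compound 3 to compound 4 (0.27 log units; within the scatter) is expected to be modest, toward weaker, and may well fall within the scatter. Compound 4 is estimated at 1000 nM, within 250 nM to 5000 nM.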

Compound 4, half-maximal inhibitory concentration: 670 nM
Compound 4: the middle estimate sits 1.5-fold (0.17 log units) above what was measured; the range from low to high includes it.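

With methoxy in place of chloro on an aromatic carbon, para to a large group, this assay gives a 1.2-fold higher number from compound 3 to compound 4 (0.09 log units; within the scatter), so the two groups cannot be told apart at this position. Among the compounds shown here, compound 3 and compound 4 form the only pair here that differs in one place, and this step is the first direct reading of the position. Nothing at hand accounts for this result. Going by these compounds, whether an amine or a carboxylic acid at this position would read the same stays open. So does whether a longer chain in place of methoxy would hold that level.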